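Moving the methyl group on the ring nitrogen substituent

A few compounds are considered here, and "the series" means these few. Any claim that something is new, unique, unknown or untested is made for them only; others in the source may bear on it.

Compound 1, `Cc1ccccc1N1CC(c2nc(-c3cccc(Cl)c3)no2)CC1=O`: > 10000 nM
Compound 2, `Cc1ccc(N2CC(c3nc(-c4cccc(F)c4)no3)CC2=O)cc1`: 1200 nM

In an in vitro functional assay on HEK293-A cells for positive allosteric modulation of metabotropic glutamate receptor 5 (Homo sapiens), read by FLIPR and calcium flux (a higher number here means that more compound is needed for the effect, a lower number that less compound is needed), compound 1 gives > 10000 nM. That figure is a limit of the assay, not a measured number, so compound 1 stands at the limit of > 10000 nM in this assay, at which 1 of the 2 values shown sits, and its true value is not known. Compound 2 gives 1200 nM in this assay. Compound 2 differs from compound 1 in two places at once, so the two values can only be set side by side, and no single step can be read from them.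

Compound 3, `Cc1cccc(N2CC(c3nc(-c4cccc(Cl)c4)no3)CC2=O)c1`, has not yet been measured. It differs from compound 1 in one place only: 3-methylphenyl in place of 2-methylphenyl on an amide-type nitrogen in a ring. Because compound 1 sits at the limit (the limit of > 10000 nM in this assay, at which 1 of the 2 values shown sits), a step toward lower numbers, beyond the usual scatter, is expected, roughly an at least 4.0-fold lower number from compound 1 to compound 3 (0.60 log units; beyond the scatter). Compound 3 is estimated to give about 2500 nM, within a range from 600 nM to 10000 nM.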

Compound 3, half-maximal effective concentration: > 10000 nM
Compound 3: only a limit was reported (the forecaster's own chance of this, stated with the estimate: 30%); middle value at least 4.0-fold (0.60 log units) from the limit.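

No step can be read from compound 1 to compound 3, because both values are limits of the assay and not numbers: the limit of > 10000 nM in this assay, at which 2 of the 3 values shown sit. The compounds shown leave open whether 3-methylphenyl in place of 2-methylphenyl changes the number at all.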